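The source may hold more compounds than are shown below. What is called first, only, known or untested is meant among the compounds shown, and "the series" means these compounds.

Of the compounds shown here, two from this series have been measured in an assay on L cells for inhibition of Protein-serine O-palmitoleoyltransferase porcupine (Mus musculus), read by reporter gene assay, with a stated time of 24 h; a lower number here means that less compound is needed, a higher number that more compound is needed for the effect. Compound 1 `COc1ccc(-n2nc(C(=O)NCC(=O)Nc3nc4ccc(C)cc4s3)c3ccccc3c2=O)cc1` gives 25 nM in this assay. Compound 2 `O=C(CNC(=O)c1nn(-c2ccc(F)cc2)c(=O)c2ccccc12)Nc1nc2ccc(C(F)(F)F)cc2s1` gives 90 nM in this assay, the higher of the two numbers, and its gap from compound 1 lies beyond the scatter. Compound 3 `Cc1ccc2nc(NC(=O)CNC(=O)c3nn(-c4ccc(F)cc4)c(=O)c4ccccc34)sc2c1` has not yet been measured. It differs from compound 2 in one place: methyl in place of trifluoromethyl on an aromatic carbon. For the measured compounds named here, no directly comparable pair among the measured compounds isolates this change, so the expectation must rest on the values shown. Because compound 1 gives 25 nM while compound 2 gives 90 nM, a modest downward step is expected, though it may fall within the scatter. The step from compound 2 to compound 3 is therefore estimated at a 2.3-fold lower number from compound 2 to compound 3 (0.35 log units; beyond the scatter). For compound 3 the expected value in this assay is 40 nM, within a range from 15 nM to 110 nM.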

Compound 3, half-maximal effective concentration: 100 nM
Estimate against measurement, compound 3: 2.5-fold (0.40 log units) below; the measured number falls inside the stated range.
By their numbers in this assay, from the lowest: compound 1; then compounds 2 and 3 (each within the scatter of the next).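

In this assay putting methyl in place of trifluoromethyl on this aromatic carbon gives a 1.1-fold higher number from compound 2 to compound 3 (0.05 log units; within the scatter) and so does not separate the two groups at this position. Compound 1 and compound 3 instead show a readable difference with the methyl held constant, where fluoro in place of methoxy on an aromatic carbon gives a 4.0-fold higher number from compound 1 to compound 3 (0.60 log units; beyond the scatter) in this assay and is the only step shown here that lies beyond the scatter. Nothing available explains either outcome.

From the compounds shown here alone, it remains open whether an amine, a carboxylic acid or a longer alkyl chain on the same aromatic carbon would give a number apart from those of methyl and trifluoromethyl. Going by these compounds, it also remains open whether fluoro in place of methoxy would give a similar step with trifluoromethyl at this position.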